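Replacing Pyridin-2-yl with 1,2,4-Triazol-1-yl in Compound 4

A few compounds are considered here, and "the series" means these few. Any claim that something is new, unique, unknown or untested is made for them only; others in the source may bear on it.

Compound 1 `Cc1cc(C)c(NC(=O)N(Cc2cc(-c3ccccc3)cs2)C2CCCCCC2)c(C)c1`: 36 nM
Compound 2 `O=C(Nc1c(F)cc(F)cc1F)N(Cc1ccc(-c2ccccn2)cc1)C1CCCCCC1`: 25 nM
Compound 3 `Cc1cc(C)c(NC(=O)N(Cc2ccc(-c3ccccn3)cc2)C2CCCCCC2)c(C)c1`: 33 nM

Of the compounds shown here, three sharing one core have been measured in an assay on microsomes from intestine for inhibition of acyl-CoA:cholesterol acyltransferase (Oryctolagus cuniculus); a higher number here means a weaker inhibitor, a lower number a stronger inhibitor. Compound 3 `Cc1cc(C)c(NC(=O)N(Cc2ccc(-c3ccccn3)cc2)C2CCCCCC2)c(C)c1` gives 33 nM, the second highest of the three numbers; its nearest neighbour is compound 1 with 36 nM and its furthest is compound 2 with 25 nM, and both of those gaps lie within the usual scatter. Within the data shown here, the one measured step, a 1.3-fold higher number from compound 2 to compound 3 (0.12 log units; within the scatter), exchanges a group on the amide-type nitrogen and stays within the scatter as well.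

Compound 4 `Cc1cc(C)c(NC(=O)N(Cc2ccc(-n3cncn3)cc2)C2CCCCCC2)c(C)c1` differs from compound 3 at the other end of the molecule: 1H-1,2,4-triazol-1-yl in place of pyridin-2-yl on an aromatic carbon. Among the measured compounds shown here, no measured step touches that position, so the measured step gives no direct guide, and compounds 1 and 3, which differ at that end in more than one place, only show numbers within the scatter of each other. With all three numbers so close, the step of a 1.5-fold higher number from compound 3 to compound 4 (0.18 log units; within the scatter) is expected to be small, with a slight lean toward a higher number. Compound 4 is therefore estimated at 50 nM in this assay, within a range from 20 nM to 130 nM.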

Compound 4, half-maximal inhibitory concentration: 26 nM
For compound 4 the middle estimate is 1.9-fold (0.28 log units) above the measured one, within the range that was stated.
By their numbers in this assay, from the lowest: compounds 2, 4, 3 and 1 (each within the scatter of the next).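

Among these compounds, this is the first measured exchange at this end of the molecule. On an aromatic carbon of a six-membered aromatic ring of carbon only, para to a large group, 1H-1,2,4-triazol-1-yl replaces pyridin-2-yl, and this assay records a 1.3-fold lower number from compound 3 to compound 4 (0.10 log units; within the scatter) for the exchange, so the change in ring and in hydrogen-bond acceptors leaves the number within what repeated measurements would give: one six-membered aromatic ring with 1 hetero atom and 1 hydrogen-bond acceptor gives way to one five-membered aromatic ring with 3 hetero atoms and 3 hydrogen-bond acceptors. No measurement at hand offers an explanation for this result.

Going by these compounds, it remains open whether a group of a different kind at this position, such as an amine or a carboxylic acid in place of the aromatic ring, would also keep the number within the scatter in this assay. On these data alone, it is equally open whether 1H-1,2,4-triazol-1-yl would give a similar result alongside the 2,4,6-trifluorophenyl group of compound 2.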